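A few compounds are considered here, and "the series" means these few. Any claim that something is new, unique, unknown or untested is made for them only; others in the source may bear on it.

Measured in an ADME assay on cells (spleen, Mus musculus, strain C57BL/6) for inhibition, read by flow cytometry and propidium iodide staining, with a stated time of 24 h, at 37 degrees C; a higher number here means that more compound is needed for the effect, a lower number that less compound is needed:
compound 1 `O=C(Cn1cc(CO)nn1)NCc1ccccc1`: 490 uM
compound 2 `O=C(O)CCc1cn(CC(=O)NCc2ccccc2)nn1`: 1420 uM

Compound 2 holds the higher of the two numbers, at 1420 uM. Compound 3 `CC(C)(C)OC(=O)NCc1cn(CC(=O)NCc2ccccc2)nn1` carries (tert-butoxycarbonyl)amino in place of carboxymethyl on a saturated chain carbon bound to an aromatic carbon. Among the compounds with values here, only one measured step bears on this place: a 2.9-fold higher number from compound 1 to compound 2 (0.46 log units; beyond the scatter), modest and beyond the scatter. A single step shows no trend, so the expectation is weak. A modest step toward a lower number is expected in this assay. The expected step is a 2.4-fold lower number from compound 2 to compound 3 (0.37 log units; beyond the scatter). The estimated value for compound 3 is 600 uM, with an expected range of 200 uM to 1800 uM.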

Compound 3, concentration for half-maximal effect: > 2000 uM
Compound 3: no number, only a limit (the forecaster's own chance of this, stated with the estimate: 20%); at least 3.3-fold (0.52 log units) between middle value and limit.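

In this assay compound 3 gives only a limit, not a number: the limit of > 2000 uM in this assay, at which 1 of the 3 values shown sits. Replacing hydroxy with (tert-butoxycarbonyl)amino on this saturated chain carbon gives an at least 4.0-fold higher number from compound 1 to compound 3 (0.61 log units; beyond the scatter), so both replacements of hydroxy shown now point toward a higher number. The other step, an at least 1.4-fold higher number from compound 2 to compound 3 (0.14 log units; that floor lies within the scatter), has a floor that does not separate these two replacements.

On these data alone, the actual value of compound 3 remains open. As far as these compounds go, it is also open whether a free amine or a longer chain ending in hydroxy at this position would stay near compound 1.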